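The source may report more compounds than this note shows. Statements on the series, on what has been measured and on what is new or still open speak of the compounds shown alone.

Measured compounds:
Compound 1, `COC(OC)[C@]1(C)Oc2ccc(N)cc2[C@H](/N=C(\NC#N)NCc2ccccc2)[C@H]1O`: 4100 nM
Compound 2, `COC(OC)[C@]1(C)Oc2ccc(N)cc2[C@@H](/N=C(\NC#N)NCc2ccccc2)[C@@H]1O`: 8000 nM
Compound 3, `COC(OC)[C@]1(C)Oc2ccc(N)cc2[C@H](/N=C(\NC#N)NCc2ccccc2)[C@@H]1O`: 2200 nM

All three were tested in a functional assay (neuronal) with Rattus norvegicus as the target, read by LDH release, tested at 30 uM; on this read-out lower numbers stand for stronger inhibition and higher numbers for weaker inhibition. Compound 3 sits at the low end of the set: the step of a 3.6-fold lower number from compound 2 to compound 3 (0.56 log units; beyond the scatter) is beyond the scatter, whereas the step of a 1.9-fold lower number from compound 1 to compound 3 (0.27 log units; within the scatter) is within it, so compound 3 and compound 1 cannot be told apart. The step of a 2.0-fold higher number from compound 1 to compound 2 (0.29 log units; within the scatter) is likewise within the scatter. Every measured step rests on (the fact that compounds 1 and 2 differ only in the configuration as drawn), the fact that compounds 1 and 3 differ only in the configuration as drawn or (the fact that compounds 2 and 3 differ only in the configuration as drawn); the three compounds share every atom and bond and differ only in how the saturated ring carbons are drawn.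

Compound 4, `COc1ccc(CN/C(=N/[C@H]2c3cc(N)ccc3O[C@@](C)(C(OC)OC)[C@H]2O)NC#N)cc1`, has not yet been measured. It differs from compound 3 by methoxy in place of hydrogen on an aromatic carbon. Going by the values given here, none of the measured steps bears on this change: they all concern configuration, and no pair among the measured compounds differs by a methoxy on an aromatic carbon. Among the compounds with values here, with no comparable step to lean on, the expectation for compound 4 in this assay is a number close to that of compound 3, with no step beyond the scatter in either direction. Compound 4 is therefore estimated at 2500 nM, spanning 800 nM to 8000 nM, which means an expected step of a 1.1-fold higher number from compound 3 to compound 4 (0.06 log units; within the scatter).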

Compound 4, half-maximal inhibitory concentration: 4100 nM
The estimate for compound 4 lay 1.6-fold (0.21 log units) below the measured number; measured number inside the range.
By their numbers in this assay, from the lowest: compounds 3, 1, 4 and 2 (each within the scatter of the next, the first and the last beyond it).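

In this assay the change from benzyl to 4-methoxybenzyl gives a 1.9-fold higher number from compound 3 to compound 4 (0.27 log units; within the scatter) and so stays within the scatter, which means that compound 3 and compound 4 cannot be told apart. The earlier compounds shown here differed only in configuration and said nothing about the benzyl group, whereas this pair shows that a methoxy in place of hydrogen on this aromatic carbon, para to a large group, does not produce a step beyond the scatter on this read-out. What is known about these compounds concerns only their configuration and does not bear on this substitution.

This single pair leaves open whether a chlorine, a hydroxyl, an ethoxy or a carboxylic acid on the same aromatic carbon would also stay within the scatter, or would shift the number clearly in either direction. It also leaves open whether the 4-methoxybenzyl group would behave in the same way on the configurations drawn in compound 1 and compound 2, since it is shown here only on the configuration of compound 3.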